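Homologation of the hydroxymethyl arm on the piperidine series

The source may report more compounds than this note shows. Statements on the series, on what has been measured and on what is new or still open speak of the compounds shown alone.

Measured so far:
compound 1 `C=CCc1cc(O)c(O)c(CN2CCC(CO)CC2)c1` — 5.4%
compound 2 `C#CCOc1ccc(CC=C)cc1O` — 5.6%

Both compounds were tested in a functional assay on HepG2 cells (Homo sapiens) for inhibition, read by MTT assay, with a stated time of 72 h, tested at 50 uM; a lower number here means less inhibition of growth, a higher number more inhibition of growth at the concentration tested. Compound 1 gives 5.4% and compound 2 gives 5.6%; the two values lie within the scatter of each other, so neither can be set apart from the other. On the numbers shown, compound 1 sits with its value at the low end of what was measured, with no other compound beyond the scatter of it.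

Compound 3 `C=CCc1cc(O)c(O)c(CN2CCC(CCO)CC2)c1` is the next compound for this assay. It differs from compound 1 in one place: hydroxymethyl in place of hydroxy on a saturated chain carbon bound to a saturated ring carbon. Among the compounds with values here, no step between measured compounds is known for this kind of change, so the expectation rests on compound 1 alone, whose value 5.4% sits near the bottom of the read-out.

Compound 3 is expected to show a step of a number 1.6 percentage points higher from compound 1 to compound 3 (within the scatter), that is, no change beyond the scatter. The estimate for compound 3 is 7%, within a range from 0% to 20%.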

Compound 3, percent growth inhibition at one concentration: 2%
For compound 3 the middle estimate is 5 percentage points above the measured one; measured number inside the range.
By their numbers in this assay, from the lowest: compounds 3, 1 and 2 (each within the scatter of the next).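

In this assay, within the data shown here, the change from hydroxymethyl to 2-hydroxyethyl on a saturated chain carbon bound to a saturated ring carbon gives a number 3.4 percentage points lower from compound 1 to compound 3 (within the scatter) and is the first step read at this position. The change therefore does not set compound 3 apart from compound 1, and both compounds remain low on the read-out at the one concentration tested. No measurement is at hand that bears on the reason for this result.

Going by these compounds, it remains open whether a longer chain such as 3-hydroxypropyl, an amine or a carboxylic acid at this place would move the value beyond the scatter. With values this low, the pair also cannot show whether this position has any influence on growth inhibition in this assay at all.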